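This account rests on a few compounds, and the source may have more. Where it says the series, first, only, none or still open, it means among the compounds named here.

Working notes on the series, read in a functional assay on MT4 cells (Homo sapiens) for inhibition; on this read-out higher numbers stand for weaker inhibition and lower numbers for stronger inhibition. Compound 1 `C=C1[C@H](n2cnc3c(N)nc(N)nc32)O[C@H](CO)[C@H]1O` gives > 500000 nM, which is a limit and not a number. Compound 2 `C=C1[C@H](n2cnc3c(N(C)C)nc(N)nc32)O[C@H](CO)[C@H]1O` gives > 500000 nM, again a limit. Among the compounds with values here, compound 3 `C=C1[C@H](n2cnc3c(OC)nc(N)nc32)O[C@H](CO)[C@H]1O`, the methoxy member, gives 180000 nM, the only true number in the set, so it is the sole firm reference point.

Compound 4 `C=C1[C@H](n2cnc3c(S)nc(N)nc32)O[C@H](CO)[C@H]1O` carries sulfanyl in place of methoxy on an aromatic carbon. Within the data shown here, no measured step involves sulfanyl, so the evidence is indirect. The two steps that bear on the change are those that install the departing methoxy: an at least 2.7-fold lower number from compound 1 to compound 3 (0.44 log units; beyond the scatter), and an at least 2.7-fold lower number from compound 2 to compound 3 (0.44 log units; beyond the scatter). Among the measured compounds shown here, both are modest lower bounds, and they show only that the two other groups tried at this carbon, amino and dimethylamino, both read weaker than methoxy. Losing methoxy may therefore give back some of that gain, so a small move towards a higher number is expected, with no large step in either direction.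

The expected step is a 1.6-fold higher number from compound 3 to compound 4 (0.19 log units; within the scatter). For compound 4 the estimated value is 280000 nM, with an expected range of 90000 nM to 600000 nM. A report as a limit only would also fit this expectation.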

Compound 4, half-maximal inhibitory concentration: 480 nM
Beside the measured number, compound 4's estimate is 580-fold (2.77 log units) above it, and the stated range ends above it.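

The change to sulfanyl on this aromatic carbon, next to the ring nitrogen, gives the first large move in the series: in this assay there is a 380-fold lower number from compound 3 to compound 4 (2.57 log units; beyond the scatter), whereas the earlier readable steps at this carbon were lower bounds of modest size. Against dimethylamino and amino the readings are an at least 1000-fold lower number from compound 2 to compound 4 (3.01 log units; beyond the scatter) and an at least 1000-fold lower number from compound 1 to compound 4 (3.01 log units; beyond the scatter), both bounds and not sizes, as the values of compound 1 and compound 2 are limits of the assay: the limit of > 500000 nM in this assay, at which 2 of the 4 values shown sit. Compound 4 is therefore the strongest of the four, and the series now shows that the group on this carbon can shift the read-out far more than amino, dimethylamino and methoxy had suggested.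

As far as these compounds go, whether the gain belongs to the sulfur atom itself or to the free sulfanyl hydrogen stays open, and methylsulfanyl or ethylsulfanyl at this carbon would separate the two. From the compounds shown here alone, how a hydroxyl group or a chlorine atom at the same carbon would read also remains open.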